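Extending the Chain: What Compound 3 May Show

A few compounds are considered here, and "the series" means these few. Any claim that something is new, unique, unknown or untested is made for them only; others in the source may bear on it.

Compound 1 (`CCCCCCn1c(N)c(N)c(=O)[nH]c1=O`) gives 1.01 in a physicochemical assay for lipophilicity; a higher number here means a more lipophilic compound, a lower number a more polar compound
Compound 2 (`CCCCCCCCn1c(N)c(N)c(=O)[nH]c1=O`) gives 2.05 in this assay

Of these two numbers, compound 2 holds the higher, at 2.05 on this scale, and it has only compound 1 to be compared with. Compound 3 (`CCCCCCCCCCn1c(N)c(N)c(=O)[nH]c1=O`) has not yet been measured. Relative to compound 2, it carries ethyl in place of hydrogen on a saturated chain carbon, eight bonds along the chain from an aromatic nitrogen. Among the compounds with values here, one measured step bears on this change. It is the same replacement made six bonds along the chain, and it is large: a number 1.04 log units higher from compound 1 to compound 2 (beyond the scatter) in this assay on the shared core. A single step cannot establish a trend, so the expectation rests on this one precedent alone. A rise of similar size is expected, and the estimated step is a number 1.00 log units higher from compound 2 to compound 3 (beyond the scatter) on that basis. The estimate for compound 3 is 3.05 with an expected range from 2.65 to 3.4 on the same scale.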

Compound 3, partition coefficient: 3.04
Compound 3: middle estimate off by 0.01 log units, on the high side, and the stated range covers the measured number.
By their numbers in this assay, from the lowest: compound 1; then compound 2; then compound 3.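

In this assay the replacement of hydrogen by ethyl now has a second reading further out, eight bonds along the chain from an aromatic nitrogen, where it gives a number 0.99 log units higher from compound 2 to compound 3 (beyond the scatter) on the shared core, so the rise is no longer tied to the single place six bonds along the chain from an aromatic nitrogen. Read as one change, butyl in place of hydrogen, six bonds along the chain from an aromatic nitrogen, gives a number 2.03 log units higher from compound 1 to compound 3 (beyond the scatter) and thus spans the whole series, in which each extension of the chain so far goes with a higher number and no compound goes against that. Nothing shown here gives a measured reason for the rise along these three compounds.

Going by these compounds, whether a longer chain than that of compound 3 would continue the rise, or where it would stop, remains open, since three compounds cannot settle how far the pattern runs. On these data alone, it is also open what the same core would give with a chain that ends in a carboxylic acid, an amine or a phenyl ring. Every chain here is a plain unbranched one.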